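Trifluoromethyl swap on the aryl group of compound 3

This account rests on a few compounds, and the source may have more. Where it says the series, first, only, none or still open, it means among the compounds named here.

In a functional assay on B16-F0 cells (Mus musculus) for inhibition, read by CCK-8 assay, with a stated time of 48 h (on this read-out lower numbers stand for stronger inhibition and higher numbers for weaker inhibition), compound 1 (`COc1cc(-c2ccnc3cc(-c4cn(CO)c5ccccc45)nn23)cc(OC)c1OC`) gives 93 nM and compound 3 (`COc1cc(-c2ccnc3cc(-c4ccc(C)c(C)c4)nn23)cc(OC)c1OC`) gives 391 nM as its read-out. Compound 3 thus holds the higher of the two numeric values, and its gap to compound 1 lies beyond the scatter. Compound 2 (`COc1cc(-c2cc3nccc(-c4c[nH]c5ccccc45)n3n2)cc(OC)c1OC`) shows > 10000 nM in this assay and that entry is a limit, not a number.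

The next step leads to compound 4 (`COc1cc(-c2ccnc3cc(-c4ccc(C(F)(F)F)cc4)nn23)cc(OC)c1OC`), with 4-(trifluoromethyl)phenyl in place of 3,4-dimethylphenyl on an aromatic carbon. Among the measured compounds shown here, no measured pair isolates this change in this assay so the expectation rests on compound 3 at 391 nM alone. A small rise in the number, probably within the scatter, is expected, and the estimated change is a 1.7-fold higher number from compound 3 to compound 4 (0.22 log units; within the scatter) for this swap. For compound 4 the estimated value is 650 nM with an expected range from 150 nM to 3000 nM for now.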

Compound 4, half-maximal inhibitory concentration: 1770 nM
For compound 4 the middle estimate is 2.7-fold (0.44 log units) below the measured one; low and high end bracket the measured number.
By their numbers in this assay, from the lowest: compound 1; then compound 3; then compound 4. At a limit, above all of these: compound 2.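

In this assay, among the compounds shown here, the only single-place step read so far, 4-(trifluoromethyl)phenyl in place of 3,4-dimethylphenyl, gives a 4.5-fold higher number from compound 3 to compound 4 (0.66 log units; beyond the scatter). The aryl group on this aromatic carbon of the five-membered ring therefore bears on the read-out, and this swap moves it toward weaker inhibition. The step can be read as a true number, and compound 2 is the only entry that is a limit and not a number: the limit of > 10000 nM in this assay, at which 1 of the 4 values shown sits.

Going by these compounds, whether the change follows from adding the trifluoromethyl group or from removing the two methyl groups stays open; the swap does both at once. Also open, on these data alone, is how a phenyl ring carrying a single methyl group, an amine or a carboxylic acid would read at this position.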